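Swapping a Furan for a Pyridine on an Oxazole Ketone

The source may hold more compounds than are shown below. What is called first, only, known or untested is meant among the compounds shown, and "the series" means these compounds.

Three compounds have been measured in an assay on isolated protein for inhibition of Fatty-acid amide hydrolase 1 (Homo sapiens); on this read-out lower numbers stand for stronger inhibition and higher numbers for weaker inhibition:
Compound 1 , `CCCCCCCC/C=C\CCCCCCC(=O)c1ncc(-c2ccoc2)o1`, gives 610 nM.
Compound 2 , `CCCCCCCC/C=C\CCCCCCC(=O)c1nc2cnccc2o1`, gives 7.2 nM.
Compound 3 , `CCCCCCCC/C=C\CCCCCCC(=O)c1ccccn1`, reaches only a limit of the assay, > 100000 nM.

Compound 1 stands highest of the two numbers actually reported; compound 2 shows a far lower number. Compound 3 sits at the limit of > 100000 nM in this assay, at which 1 of the 3 values shown sits. Among the measured compounds shown here, the only single-place step measured is an at least 13000-fold higher number from compound 2 to compound 3 (4.14 log units; beyond the scatter), showing that removing the five-membered ring together with its fused six-membered ring leaves almost no inhibition. Compound 4 , `CCCCCCCC/C=C\CCCCCCC(=O)c1ncc(-c2ccccn2)o1`, keeps that five-membered ring and changes only the group attached to it: pyridin-2-yl in place of furan-3-yl on an aromatic carbon. For the measured compounds named here, no measured step covers this exact exchange, so the step from compound 2 to compound 3 bears on it only indirectly, by marking how strongly this part of the molecule can influence the result. Compound 2, which carries a six-membered nitrogen ring fused to the core, gives the lowest number shown, 7.2 nM, and compound 4 likewise carries a six-membered nitrogen ring in this part of the molecule. Compound 4 is therefore expected to show a lower number than compound 1, a step of a 12-fold lower number from compound 1 to compound 4 (1.09 log units; beyond the scatter). The estimate for compound 4 in this assay is 50 nM, with a range from 8 nM to 400 nM.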

Compound 4, inhibition constant: 18 nM
Beside the measured number, compound 4's estimate is 2.8-fold (0.44 log units) above it; the range from low to high includes it.
By their numbers in this assay, from the lowest: compound 2; then compound 4; then compound 1. At a limit, above all of these: compound 3.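

In this assay, the group on this aromatic carbon of the shared core proves to matter on its own: with everything else in the molecule unchanged, pyridin-2-yl in place of furan-3-yl gives a 34-fold lower number from compound 1 to compound 4 (1.53 log units; beyond the scatter). The earlier step replaced the whole group on the carbonyl carbon at once, so it could not show what one part of that group contributes, whereas this exchange of a single ring, on the carbon next to the ring oxygen, is enough on its own to produce a large change. Nothing in the data shown bears on why the number falls, so the change stands here as an observation without an explanation.

Still open, on these data alone, is whether the ring nitrogen of pyridin-2-yl matters or the six-membered ring alone is enough, a question that a plain phenyl ring, with carbon atoms only, on the same carbon would address. Also open, as far as these compounds go, is how pyridin-3-yl or pyridin-4-yl, or a pyridine ring carrying a carboxylic acid or an amine, would read in this assay.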